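Swapping a Ring Oxygen for Sulfur in a Weak Binder

This account rests on a few compounds, and the source may have more. Where it says the series, first, only, none or still open, it means among the compounds named here.

Compound 1 `Cc1ncc2nccn2c1-c1ccc(Oc2nccc3occc23)cc1C(F)(F)F`: 6900 nM
Compound 2 `FC(F)(F)c1cc(Oc2nccc3occc23)ccc1-c1cccc2nccn12`: 6900 nM

In an assay on cells for displacement of a labelled ligand from D(4) dopamine receptor (Homo sapiens), read by scintillation counting, with a stated time of 90 min (on this read-out lower numbers stand for stronger inhibition and higher numbers for weaker inhibition), compound 1 gives 6900 nM. Compound 2 stands level with it: in this assay compound 2 gives 6900 nM, and the step of no change at the digits printed from compound 1 to compound 2 (within the scatter) stays inside the scatter. Compound 3 `FC(F)(F)c1cc(Oc2nccc3ccsc23)ccc1-c1cccc2nccn12` differs from compound 2 by a group of 9 heavy atoms (7 carbon, 1 nitrogen, 1 sulfur; one five-membered aromatic ring with 1 hetero atom, one six-membered aromatic ring with 1 hetero atom) in place of a group of 9 heavy atoms (7 carbon, 1 nitrogen, 1 oxygen; one five-membered aromatic ring with 1 hetero atom, one six-membered aromatic ring with 1 hetero atom), on an oxygen on an aromatic ring. Within the data shown here, no measured step touches this part of the structure; the single known step, no change at the digits printed from compound 1 to compound 2 (within the scatter), concerns a different part and showed no change. The step from compound 2 to compound 3 is therefore expected to be no change at the digits printed from compound 2 to compound 3 (within the scatter), nothing beyond the scatter. Compound 3 is estimated at 6900 nM, between 3000 nM and 16000 nM.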

Compound 3, inhibition constant: 4900 nM
For compound 3 the middle estimate is 1.4-fold (0.15 log units) above the measured one; the measured number falls inside the stated range.
By their numbers in this assay, from the lowest: compounds 3, 1 and 2 (each within the scatter of the next).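

This is the first change shown in this part of the structure, on an oxygen on an aromatic ring. In this assay, replacing the oxygen-containing group with the sulfur-containing one gives a 1.4-fold lower number from compound 2 to compound 3 (0.15 log units; within the scatter), so this exchange of two groups of equal size leaves the binding number unmoved beyond the scatter. No measurement here bears on why the number holds. From the compounds shown here alone, both groups are two-ring aromatic systems, so it remains open whether a plain phenyl ring in this place, or one carrying an amine or a carboxylic acid, would shift the number.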